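The source may report more compounds than this note shows. Statements on the series, on what has been measured and on what is new or still open speak of the compounds shown alone.

Series notes. The shared core is that of compound 1 `Cc1nn(-c2nc(-c3ccc(Cl)c(Cl)c3)c(SC(C)C)s2)c(C(=O)O)c1-c1ccccc1`; compound 2 `Cc1nn(-c2nc(-c3ccc(Cl)c(Cl)c3)c(SC(C)C)s2)c(C(=O)O)c1Cc1ccccc1[N+](=O)[O-]` and compound 3 `CC(=O)Nc1ccc(-c2c(C)nn(-c3nc(-c4ccc(Cl)c(Cl)c4)c(SC(C)C)s3)c2C(=O)O)cc1` vary from it only in the group on one aromatic carbon. In a functional assay on BJAB cells (Homo sapiens) for antiproliferative activity, with a stated time of 4 days (on this read-out higher numbers stand for an effect only at larger amounts of compound and lower numbers for an effect already at smaller amounts), compound 1 gives 3000 nM, compound 2 gives 20000 nM and compound 3 gives 139000 nM. Compound 3 stands at the highest number of the three, beyond the scatter from both others: a 7.0-fold higher number from compound 2 to compound 3 (0.84 log units; beyond the scatter) and a 46-fold higher number from compound 1 to compound 3 (1.67 log units; beyond the scatter). The remaining measured step is a 6.7-fold higher number from compound 1 to compound 2 (0.82 log units; beyond the scatter).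

Compound 4 `COc1cc(-c2c(C)nn(-c3nc(-c4ccc(Cl)c(Cl)c4)c(SC(C)C)s3)c2C(=O)O)cc(C(F)(F)F)c1` differs from compound 3 as follows: 3-methoxy-5-(trifluoromethyl)phenyl in place of 4-acetamidophenyl on an aromatic carbon. Among the compounds with values here, two measured steps bear on this. The acetamido group on the phenyl came with a 46-fold higher number from compound 1 to compound 3 (1.67 log units; beyond the scatter), so a phenyl without acetamido, as in compound 4, suggests a return toward the number of compound 1. The second bearing step, a 7.0-fold higher number from compound 2 to compound 3 (0.84 log units; beyond the scatter), points the same way, as compound 4 also drops the acetamido. However, the methoxy and trifluoromethyl groups have no counterpart among compounds 1 to 3, and no measured step shows whether such substitution on the phenyl is tolerated. A downward step of a 17-fold lower number from compound 3 to compound 4 (1.24 log units; beyond the scatter) is therefore expected, with wide uncertainty. For compound 4 in this assay the estimate is 8000 nM, expected to fall between 1500 nM and 40000 nM.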

Compound 4, half-maximal effective concentration: 1380 nM
The estimate for compound 4 lay 5.8-fold (0.76 log units) above the measured number; measured number outside the range, below it.
By their numbers in this assay, from the lowest: compound 4; then compound 1; then compound 2; then compound 3.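

At this aromatic carbon of the shared core, read in this assay, the 3-methoxy-5-(trifluoromethyl)phenyl group shows that a substituted phenyl need not carry the loss seen with 4-acetamidophenyl: the exchange gives a 100-fold lower number from compound 3 to compound 4 (2.00 log units; beyond the scatter) on replacing 4-acetamidophenyl, and a 14-fold lower number from compound 2 to compound 4 (1.16 log units; beyond the scatter) on replacing 2-nitrobenzyl. Set against the plain phenyl, the same group gives a 2.2-fold lower number from compound 1 to compound 4 (0.34 log units; beyond the scatter) as a modest step beyond the scatter, so substitution on this phenyl can go with a lower number as well as a higher one, with compound 3 as the case going the other way. Within the data shown here, nothing measured so far gives a reason for these differences.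

On these data alone, compound 4 carries methoxy and trifluoromethyl together, and the share of each in these steps stays open, as does the effect of either group alone on the phenyl. Also open, as far as these compounds go, is how an amine or a carboxylic acid on that phenyl would read in this assay, and whether the acetamido group itself or its location on the ring accounts for the high number of compound 3.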